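This account rests on a few compounds, and the source may have more. Where it says the series, first, only, none or still open, it means among the compounds named here.

Compound 3, `O=c1ccc(-c2ccc3cn[nH]c3c2)cn1Cc1ccccc1`, gives 75 nM in an assay for inhibition of MAP kinase-interacting serine/threonine-protein kinase 2 (Homo sapiens), read by luminescence and ADP-Glo, with a stated time of 2 h (a higher number here means a weaker inhibitor, a lower number a stronger inhibitor), the higher of the two numbers reported. Its nearest neighbour is compound 2, `O=c1ccc(-c2ccc3cn[nH]c3c2)cn1Cc1cccc(C(F)(F)F)c1`, which gives 32 nM in this assay; the step of a 2.3-fold higher number from compound 2 to compound 3 (0.37 log units; beyond the scatter) is a modest one. Compound 1, `O=C(N1CCOCC1)n1cc(-c2ccc3cn[nH]c3c2)ccc1=O`, reaches only a limit of the assay, > 2000 nM. This limit, (the limit of > 2000 nM in this assay, at which 1 of the 3 values shown sits), means that the step of an at least 26-fold lower number from compound 1 to compound 3 (1.42 log units; beyond the scatter) can only be read as a large lower bound.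

Compound 4, `O=c1ccc(-c2ccc3cn[nH]c3c2)cn1Cc1cccc(Cl)c1`, differs from compound 3 by chloro in place of hydrogen on an aromatic carbon. Within the data shown here, of the measured steps, the one from compound 2 to compound 3 bears most directly on this change, since it also exchanges a hydrogen for a substituent on the same aromatic carbon, and it was modest. The step from compound 1 to compound 3 alters a different part of the molecule and offers no guide here. A modest lowering of the number in this assay is therefore expected for compound 4, a 1.7-fold lower number from compound 3 to compound 4 (0.22 log units; within the scatter), and its value is estimated at 45 nM, within the range 20 nM to 110 nM.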

Compound 4, half-maximal inhibitory concentration: 40 nM
Beside the measured number, compound 4's estimate is 1.1-fold (0.05 log units) above it; the measured number falls inside the stated range.
By their numbers in this assay, from the lowest: compounds 2, 4 and 3 (each within the scatter of the next, the first and the last beyond it). At a limit, above all of these: compound 1.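

In this assay, the step of a 1.9-fold lower number from compound 3 to compound 4 (0.27 log units; within the scatter) shows that chloro on this aromatic carbon, meta to a large group, cannot be told apart from hydrogen, whereas the step of a 2.3-fold higher number from compound 2 to compound 3 (0.37 log units; beyond the scatter) did separate trifluoromethyl from hydrogen. The step of a 1.3-fold higher number from compound 2 to compound 4 (0.10 log units; within the scatter) also leaves chloro and trifluoromethyl unresolved at this carbon, so compound 4 sits within the scatter of both neighbours and only the two compounds at the ends of the series are separated. The step of an at least 50-fold lower number from compound 1 to compound 4 (1.69 log units; beyond the scatter) can be read only as a lower bound: the limit of > 2000 nM in this assay, at which 1 of the 4 values shown sits.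

The compounds shown leave open whether an amine, a methoxy group or a carboxylic acid on this carbon would move the number beyond the scatter. They also leave open whether chloro on another carbon of the benzyl ring would give a similar value.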